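The compounds below may be only part of what the source reports. "The series", "measured", "known", "first", "only" and "open" are said of these compounds alone.

Measured so far in a functional assay on L1210 cells (Mus musculus) for antiproliferative activity, read by MTT assay; on this read-out lower numbers stand for stronger inhibition and higher numbers for weaker inhibition:
- Compound 1 `O=C(N/N=C/c1ccccc1)c1cn(C2CC2)c2cc(N/N=C/c3ccccc3)c(F)cc2c1=O`: <= 25000 nM, a limit
- Compound 2 `COc1ccc(/C=N/NC(=O)c2cn(C3CC3)c3cc(N/N=C/c4ccc(OC)c(O)c4)c(F)cc3c2=O)cc1O`: <= 25000 nM, a limit
- Compound 3 `O=C(N/N=C/c1ccccc1)c1cn(C2CC2)c2cc(N3CCNCC3)c(F)cc2c1=O`: <= 25000 nM, a limit

Compound 3 gives <= 25000 nM, which is a limit and not a number. This is the limit of <= 25000 nM in this assay, at which 3 of the 3 values shown sit, so the three compounds cannot be ranked.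

Compound 4 `O=C(N/N=C/c1ccccc1[N+](=O)[O-])c1cn(C2CC2)c2cc(N3CCNCC3)c(F)cc2c1=O` differs from compound 3 by one change: nitro in place of hydrogen on an aromatic carbon. In words, this is nitro in place of hydrogen on an aromatic carbon, or phenyl to 2-nitrophenyl.

Among the measured compounds shown here, the only measured step, a step that the two limits leave unreadable from compound 1 to compound 3, involves a different group, and no measured step adds a nitro. No step beyond the scatter can therefore be expected in this assay, in either direction. The expected change is a step that the limit leaves unreadable from compound 3 to compound 4. For compound 4 the estimated value is 12000 nM, with an expected range of 3000 nM to 25000 nM.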

Compound 4, half-maximal inhibitory concentration: <= 25000 nM
Compound 4 gave a limit, no number; the forecaster's own chance of this, stated with the estimate: 65%; the middle value lies beyond the limit too.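

Among the compounds shown here, compound 3 and compound 4 both give a limit and not a number in this assay, so no step between them can be read: the limit of <= 25000 nM in this assay, at which 4 of the 4 values shown sit.
From the compounds shown here alone, how the nitro in compound 4 changes activity, and how the four compounds rank, stays open.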